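The source may report more compounds than this note shows. Statements on the series, on what has been measured and on what is new or still open speak of the compounds shown alone.

Of the compounds shown here, three built on a carbamate-bearing aryl amide scaffold have been measured in an ADME assay for metabolic stability, read by HPLC, at pH 7.4; on this read-out higher numbers stand for a longer-lived compound and lower numbers for a shorter-lived compound. Compound 1 `CCCCCCNC(=O)Oc1ccc(Cl)cc1C(=O)Nc1ccc(Cl)cc1` gives 43 h in this assay. Compound 2 `CCCCCCCNC(=O)Oc1ccc(Cl)cc1C(=O)Nc1ccc(Cl)cc1` gives 43 h. Compound 3 `CCCCCCCCCCNC(=O)Oc1ccc(Cl)cc1C(=O)Nc1ccc(Cl)c(Cl)c1` gives 43 h, and so it stands level with compound 1 and compound 2 at the digits given.

The difference between compound 1 and compound 2 is methyl in place of hydrogen on a saturated chain carbon, six bonds along the chain from an amide-type nitrogen. The measured step, no change at the digits printed from compound 1 to compound 2 (within the scatter), shows that lengthening the chain at that place left the half-life where it was. How the core of compound 3 differs from the core of compound 1 is not broken down here.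

Compound 4 `CCCCCCCCCCCNC(=O)Oc1ccc(Cl)cc1C(=O)Nc1ccc(Cl)c(Cl)c1`, not yet measured, differs from compound 3 by methyl in place of hydrogen on a saturated chain carbon, ten or more bonds along the chain from an amide-type nitrogen. Within the data shown here, this is the same kind of change as the one from compound 1 to compound 2, but the place is not the same: in the new pair the carbon sits further out along the chain from the amide-type nitrogen than in the earlier pair.

Given that every measured compound sits at one value, a flat outcome is expected because no change at the digits printed from compound 1 to compound 2 (within the scatter) came from the same kind of change. Compound 4 is expected to give about 43 h in this assay, most likely between 25 h and 75 h. The estimate for compound 4 means an expected step of no change at the digits printed from compound 3 to compound 4 (within the scatter).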

Compound 4, half-life: 43 h
Compound 4: middle estimate and measured number agree at the digits printed; the measured number falls inside the stated range.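

Putting methyl in place of hydrogen on a saturated chain carbon, ten or more bonds along the chain from an amide-type nitrogen, gives no change at the digits printed from compound 3 to compound 4 (within the scatter) in this assay. Set beside the earlier lengthening of the chain on the core of compound 1, the same kind of change reads alike on both cores: the same change on two cores in this assay, no change at the digits printed (within the scatter) from compound 1 to compound 2 and no change at the digits printed (within the scatter) from compound 3 to compound 4, 1.0-fold (0.00 log units) apart, within the scatter of two such steps This shows that, for these two pairs, adding methyl to the chain leaves the half-life level whichever of the two cores carries it, but it does not show a general rule, since neither step moved the number, the two changes sit at different places along the chain, and a change that does move the half-life has yet to be followed from one core to another.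

All four compounds shown carry a long saturated chain on the same carbamate link, so it stays open whether a much shorter chain such as propyl, or a chain carrying an amine or a carboxylic acid, would read differently. On these data alone, it also stays open whether a carbon chain ending in a phenyl ring, or an amide in place of the carbamate, would keep the half-life where these compounds stand.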